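A few compounds are considered here, and "the series" means these few. Any claim that something is new, unique, unknown or untested is made for them only; others in the source may bear on it.

Working notes on the series

Of the compounds shown here, three have been measured. Compound 1 `CCC(CC)(c1ccc(OS(=O)(=O)c2ccc(C)cc2)c(C)c1)c1ccc(OCC(O)C(C)(C)C)c(OCC(O)C(C)(C)C)c1`, compound 2 `CCC(CC)(c1ccc(OCCO)c(C)c1)c1ccc(OCC(O)C(C)(C)C)c(OCC(O)C(C)(C)C)c1` and compound 3 `CCC(CC)(c1ccc(OCC(=O)O)c(C)c1)c1ccc(OCC(O)C(C)(C)C)c(OCC(O)C(C)(C)C)c1` share one core and differ only in the group on one aromatic oxygen. In an assay on cells for binding affinity to vitamin D3 receptor (Homo sapiens), read by fluorescence, tested at 1 uM (a lower number here means less inhibition, a higher number more inhibition at the concentration tested (going by the name of the read-out)), compound 1 gives 43%, compound 2 gives 38% and compound 3 gives 10%. Compound 3 therefore stands lowest of the three: its nearest neighbour is compound 2, separated by a number 28 percentage points lower from compound 2 to compound 3 (beyond the scatter), and its furthest is compound 1, separated by a number 33 percentage points lower from compound 1 to compound 3 (beyond the scatter). The step of a number 5 percentage points lower from compound 1 to compound 2 (within the scatter) shows that the first two compounds are not distinguishable in this assay.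

Compound 4 `CCC(CC)(c1ccc(OCCCCCC(=O)O)c(C)c1)c1ccc(OCC(O)C(C)(C)C)c(OCC(O)C(C)(C)C)c1` is the next candidate. Its difference from compound 3 is 4-carboxybutyl in place of carboxy on a saturated chain carbon bound to an oxygen on an aromatic ring. Within the data shown here, the only measured step touching the carboxy group at this position is a number 28 percentage points lower from compound 2 to compound 3 (beyond the scatter), which compares carboxy with hydroxymethyl; no measured step lengthens a chain on this oxygen, so the effect of the added carbons is not covered by the data. Compound 4 keeps the carboxy, so the expectation leans toward a value near compound 3, with the spread of compound 2 and compound 1 marking the plausible upper region. An upward step of a number 10 percentage points higher from compound 3 to compound 4 (within the scatter) is expected, possibly within the scatter. Compound 4 is estimated at 20%, ranging from 5% to 45%.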

Compound 4, a percentage reported as inhibition, at one concentration (the size of the read-out at that concentration, not a potency): "not active" (no number reported)
The entry for compound 4 holds no number, so the estimate cannot be set against anything.
By their numbers in this assay, from the lowest: compound 3; then compounds 2 and 1 (each within the scatter of the next).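

Among these compounds, compound 4 is entered as "not active" in this assay, with no number, so no step linking it to compound 3 or any other compound can be read. No measurement shown bears on this entry. What the compounds shown leave open is how lengthening the chain that carries the carboxy group on this oxygen affects the read-out.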